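Compound 4: what the limits leave open

The source may hold more compounds than are shown below. What is called first, only, known or untested is meant among the compounds shown, and "the series" means these compounds.

Measured in a functional assay on A549 cells (Homo sapiens), read by MTT assay, with a stated time of 72 h; a higher number here means a weaker inhibitor, a lower number a stronger inhibitor:
Compound 1 `CSc1ncnc2c1c(-c1ccsc1)cn2[C@@H]1O[C@H](CO)[C@@H](O)[C@H]1O`: > 20000 nM (a limit)
Compound 2 `Nc1nc(N)c2c(-c3ccco3)cn([C@@H]3O[C@H](CO)[C@@H](O)[C@H]3O)c2n1`: > 20000 nM (a limit)
Compound 3 `Cc1nc(N)c2c(-c3ccco3)cn([C@@H]3O[C@H](CO)[C@@H](O)[C@H]3O)c2n1`: > 20000 nM (a limit)

Compound 3 stands at > 20000 nM in this assay. This is a limit of the assay and not a number. The other compounds offer no firmer reference point: the limit of > 20000 nM in this assay, at which 3 of the 3 values shown sit.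

Compound 4 `C#Cc1cn([C@@H]2O[C@H](CO)[C@@H](O)[C@H]2O)c2nc(C)nc(N)c12` keeps the core of compound 3, but ethynyl takes the place of furan-2-yl on an aromatic carbon: ethynyl in place of furan-2-yl on an aromatic carbon.

Among the compounds with values here, the one measured step is a step that the two limits leave unreadable from compound 2 to compound 3. It concerns methyl in place of amino, not the group changing here, and it has no readable size to carry over. Within the data shown here, no measured step therefore sets a size or direction for the change in this assay. Among the measured compounds shown here, the only guide is where compound 3 and its companions sit, so a value near the limit is the expectation, with a wide margin towards stronger inhibition because the new group is untested.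

The estimated change is an at least 1.3-fold lower number from compound 3 to compound 4 (0.12 log units; that floor lies within the scatter). For compound 4, the expected value is 15000 nM, with an estimated range from 1500 nM to 40000 nM.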

Compound 4, half-maximal inhibitory concentration: > 20000 nM
Compound 4 ended at the assay's limit (the forecaster's own chance of this, stated with the estimate: 60%); middle value at least 1.3-fold (0.12 log units) away from the limit.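

Within the data shown here, compound 3 and compound 4 both sit at a limit of the assay and not at a number, so the change from furan-2-yl to ethynyl gives no step that can be read. The compounds shown leave open how strong any of them really is in this assay, and whether either group makes a difference there: the limit of > 20000 nM in this assay, at which 4 of the 4 values shown sit.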